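Pyridin-2-yl in Place of Benzyl: Expected Cytotoxicity

The source may hold more compounds than are shown below. What is called first, only, known or untested is meant among the compounds shown, and "the series" means these compounds.

Among the measured compounds shown here, compound 2 `CC(=O)N1CCC(C(=O)N(CCCN2CCN(Cc3ccccc3)CC2)c2ccc(C)c(Cl)c2)CC1` is the only compound with a plain number in an ADME assay (Homo sapiens) for cytotoxicity; on this read-out lower numbers stand for higher toxicity in this test and higher numbers for lower toxicity in this test; in that assay compound 2 gives 101000 nM. Compound 1 `CC(=O)N1CCC(C(=O)N(CCCN2CCN(Cc3cccnc3)CC2)c2ccc(C)c(Cl)c2)CC1` gives only a limit of the test, > 56700 nM. The step that the limit leaves unreadable from compound 1 to compound 2 is thus of unreadable size because of the limit of > 56700 nM in this assay, at which 1 of the 2 values shown sits. Compound 3 `CC(=O)N1CCC(C(=O)N(CCCN2CCN(c3ccccn3)CC2)c2ccc(C)c(Cl)c2)CC1` differs from compound 2 by pyridin-2-yl in place of benzyl on an amine nitrogen in a ring. No readable measured step bears on this change. No shift beyond the scatter of this assay is expected for compound 3, so the estimated step is a 1.2-fold lower number from compound 2 to compound 3 (0.07 log units; within the scatter). Compound 3 is expected to give 85000 nM, within 30000 nM to 250000 nM.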

Compound 3, half-maximal cytotoxic concentration: > 58300 nM
Compound 3 was reported as a limit (the forecaster's own chance of this, stated with the estimate: 40%); the middle value is on the limit's open side.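

Compound 3 gives only a limit, so neither the step from compound 2 to compound 3 nor the step from compound 1 to compound 3 can be read: the limit of > 58300 nM in this assay, at which 1 of the 3 values shown sits.

From the compounds shown here alone, how far pyridin-2-yl in place of benzyl moves the number in this assay stays open.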